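The source may hold more compounds than are shown below. What is called first, only, known or untested is meant among the compounds shown, and "the series" means these compounds.

The measured compounds in an assay on RBL-1 cells for inhibition of Polyunsaturated fatty acid 5-lipoxygenase (Rattus norvegicus); on this read-out higher numbers stand for weaker inhibition and lower numbers for stronger inhibition:

Compound 1, `COc1cc(/C=C/C=C/c2nc3ccccc3o2)ccc1O`: 330 nM
Compound 2, `COc1cc(/C=C/C=C/c2nc3cc(Cl)ccc3o2)ccc1O`: 380 nM

Among these two numbers compound 2 holds the higher one, yet its only neighbour, compound 1, lies within the scatter of it, so the two cannot be told apart on this read-out. The next compound, compound 3, `CCOC(=O)c1ccc2oc(/C=C/C=C/c3ccc(O)c(OC)c3)nc2c1`, differs from compound 2 in a single place: ethoxycarbonyl in place of chloro on an aromatic carbon.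

For the measured compounds named here, only one measured step touches this region of the shared core, a 1.2-fold higher number from compound 1 to compound 2 (0.06 log units; within the scatter), which exchanged hydrogen for chloro at that aromatic carbon and left the number essentially unchanged. Going by the values given here, no measured pair shows chloro against ethoxycarbonyl, so the larger group that enters in compound 3 has no direct precedent here. Given the flat step from compound 1 to compound 2, the account expects for compound 3 a step of a 1.1-fold higher number from compound 2 to compound 3 (0.04 log units; within the scatter), that is, no change beyond the scatter. Compound 3 is therefore estimated at 420 nM in this assay, with a range from 150 nM to 1200 nM.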

Compound 3, half-maximal inhibitory concentration: 250 nM
Estimate against measurement, compound 3: 1.7-fold (0.23 log units) above; the range from low to high includes it.
By their numbers in this assay, from the lowest: compounds 3, 1 and 2 (each within the scatter of the next).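

At this aromatic carbon, the ethoxycarbonyl group, with its 5 heavy atoms and 2 hydrogen-bond acceptors, moves the number in this assay by no more than the scatter: in place of chloro it gives a 1.5-fold lower number from compound 2 to compound 3 (0.18 log units; within the scatter), and in place of hydrogen it gives a 1.3-fold lower number from compound 1 to compound 3 (0.12 log units; within the scatter). The flat result seen so far for a single chlorine atom therefore extends to a much larger group, and hydrogen, chloro and ethoxycarbonyl cannot be told apart at this place on this read-out. No evidence at hand accounts for this flatness.

The compounds shown leave open whether a carboxylic acid, an amine or a longer ester chain at this carbon would also leave the number unchanged. They also leave open whether the other aromatic carbons of this ring behave the same way.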